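The compounds below may be only part of what the source reports. "The series", "measured", "known", "first", "only" and "open" are said of these compounds alone.

Compounds measured in an assay on brain for displacement of a labelled ligand from D(3) dopamine receptor (Rattus norvegicus); on this read-out higher numbers stand for weaker inhibition and lower numbers for stronger inhibition:
compound 1 `CCCN(CC[C@H]1CC[C@H](NC(=O)c2ccc3ccccc3n2)CC1)[C@H]1CCc2nc(N)sc2C1`: 1.6 nM
compound 2 `CCCN(CC[C@H]1CC[C@H](NC(=O)c2ccc(-n3cncn3)cc2)CC1)[C@H]1CCc2nc(N)sc2C1`: 2.4 nM
compound 3 `CCCN(CC[C@H]1CC[C@H](NS(=O)(=O)c2cccc3ccccc23)CC1)[C@H]1CCc2nc(N)sc2C1`: 1.5 nM

On these three numbers compound 3 gives the lowest value, yet its gaps to compound 1 and to compound 2 both lie within the scatter, so the three cannot be ordered. Compound 4 `CCCN(CC[C@H]1CC[C@H](NS(=O)(=O)c2ccc(C(C)C)cc2)CC1)[C@H]1CCc2nc(N)sc2C1` differs from compound 3 in one place: 4-isopropylphenyl in place of naphthalen-1-yl on a sulfonyl sulfur. Within the data shown here, no measured step touches the sulfonyl sulfur. Among the measured compounds shown here, the only step known in the set, a 1.5-fold higher number from compound 1 to compound 2 (0.18 log units; within the scatter), swaps quinolin-2-yl for 4-(1H-1,2,4-triazol-1-yl)phenyl on a carbonyl carbon and stays within the scatter. That step is the nearest analogy, a fused aromatic group giving way to a substituted phenyl on the same kind of attachment point, and it suggests that such a swap need not move this assay by more than the scatter. Compound 4 is therefore expected to show a 2.0-fold higher number from compound 3 to compound 4 (0.30 log units; within the scatter), leaning slightly toward a higher number. The estimate for compound 4 in this assay is 3 nM, with a range from 1 nM to 10 nM.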

Compound 4, inhibition constant: 4.5 nM
For compound 4 the middle estimate is 1.5-fold (0.18 log units) below the measured one; measured number inside the range.
By their numbers in this assay, from the lowest: compounds 3, 1, 2 and 4 (each within the scatter of the next, the first and the last beyond it).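

Among these compounds, at the sulfonyl sulfur, where the earlier compounds offered no step, this assay does respond to the group carried: 4-isopropylphenyl in place of naphthalen-1-yl gives a 3.0-fold higher number from compound 3 to compound 4 (0.48 log units; beyond the scatter) and so the first step in the set that passes the scatter. The step is modest, and with one six-membered aromatic ring instead of two, compound 4 still gives 4.5 nM in this read-out. Nothing measured here bears on why this swap raises the number.

The compounds shown leave open how much of the step belongs to the lost ring and how much to the isopropyl group, a split that a plain phenyl on the sulfonyl sulfur would help to settle. They also leave open how a carboxylic acid or an amine in place of the isopropyl group would read.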